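The source may report more compounds than this note shows. Statements on the series, on what has been measured and on what is new or still open speak of the compounds shown alone.

Measured so far:
compound 1 `Cc1cccc(C)c1S(=O)(=O)NC[C@@H](O)CN1CCC[C@@]2(CCN(c3ncnc(N)c3C3CC3)C2)C1` gives 900 nM
compound 2 `Cc1ccc(S(=O)(=O)NC[C@@H](O)CN2CCC[C@@]3(CCN(c4ncnc(N)c4C4CC4)C3)C2)c(C)c1` gives 18000 nM

Within the data shown here, in an assay on LNCaP cells for inhibition of RAC-alpha serine/threonine-protein kinase (Homo sapiens) (a lower number here means a stronger inhibitor, a higher number a weaker inhibitor), compound 2 has the higher of the two numbers, and the single measured step, a 20-fold higher number from compound 1 to compound 2 (1.30 log units; beyond the scatter), sets it well apart from compound 1. Compound 3 `Cc1noc(C)c1S(=O)(=O)NC[C@@H](O)CN1CCC[C@@]2(CCN(c3ncnc(N)c3C3CC3)C2)C1` differs from compound 2 by 3,5-dimethyl-1,2-oxazol-4-yl in place of 2,4-dimethylphenyl on a sulfonyl sulfur. Among the measured compounds shown here, no measured pair covers this ring exchange itself; the one step that exists concerns the methyl pattern on the phenyl ring and shows, through a 20-fold higher number from compound 1 to compound 2 (1.30 log units; beyond the scatter), that the group on the sulfonyl sulfur can move this assay by a large amount. With only that to go on, compound 3 is expected to move away from compound 2, the number estimated to fall between 500 nM and 12000 nM with a middle estimate of 2500 nM. That expectation corresponds to the step of a 7.2-fold lower number from compound 2 to compound 3 (0.86 log units; beyond the scatter) and rests on the value of compound 1, 900 nM, as the nearest available comparison.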

Compound 3, half-maximal inhibitory concentration: 490 nM
Compound 3: middle estimate off by 5.1-fold (0.71 log units), on the high side, outside the stated range (below it).
By their numbers in this assay, from the lowest: compounds 3 and 1 (each within the scatter of the next); then compound 2.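

In this assay, putting 3,5-dimethyl-1,2-oxazol-4-yl on the sulfonyl sulfur in place of 2,4-dimethylphenyl gives a 37-fold lower number from compound 2 to compound 3 (1.57 log units; beyond the scatter), which shows that this place does not need a six-membered aromatic ring of carbon only and can carry a five-membered aromatic ring with 2 hetero atoms. Set against the 2,6-dimethylphenyl group, the same ring gives a 1.8-fold lower number from compound 1 to compound 3 (0.26 log units; within the scatter), so compound 1 and compound 3 cannot be told apart here, and compound 2 alone stands apart among the three. Nothing at hand explains why these groups differ as they do.

From the compounds shown here alone, it remains open whether the 3,5-dimethyl-1,2-oxazol-4-yl ring would hold this level without its methyl groups. Going by these compounds, it is also open whether an unsubstituted phenyl, a pyridine ring or an open alkyl chain on the sulfonyl sulfur would fall with compound 1 and compound 3 or with compound 2.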